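Shortening the Side Chain of a Low-Toxicity Compound

This account rests on a few compounds, and the source may have more. Where it says the series, first, only, none or still open, it means among the compounds named here.

Compound 1 (`CCCCCCCC#Cc1cc2cn(COCCO)c(=O)nc2o1`) gives > 50000 nM in a functional assay on HEL cells (Homo sapiens) (on this read-out higher numbers stand for lower toxicity in this test and lower numbers for higher toxicity in this test), as a limit of the assay and not a number. Compound 2 (`CCCCCCCc1cc2cn(COCCO)c(O)nc-2n1`) reads 119000 nM in this assay as a true number, so it also sits at a high concentration. Compound 3 (`CCCCC#Cc1cc2cn(COCCO)c(=O)nc2o1`) keeps the core of compound 1 and differs in one place: hydrogen in place of propyl on a saturated chain carbon, four bonds along the chain from a triple-bonded carbon. Going by the values given here, no measured pair shows what this change does. Compound 2 at 119000 nM shows little toxicity, so the expectation is no step beyond the scatter in this assay and no firm direction. The expected step is a step that the limit leaves unreadable from compound 1 to compound 3 in this estimate. Compound 3 is expected near 80000 nM with an estimated range from 30000 nM to 200000 nM and may come out only as a limit.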

Compound 3, half-maximal cytotoxic concentration: > 50000 nM
Compound 3: only a limit was reported (the forecaster's own chance of this, stated with the estimate: 55%); the middle value is on the limit's open side.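

No step can be read from compound 1 to compound 3 in this assay, as both compounds are reported only at the same limit of the assay: the limit of > 50000 nM in this assay, at which 2 of the 3 values shown sit.

The compounds shown leave open where the true values of compound 1 and compound 3 lie, and so whether the shorter chain changes toxicity in this assay at all.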